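Swapping Fluoro for Chloro on the Aryl Ring

This account rests on a few compounds, and the source may have more. Where it says the series, first, only, none or still open, it means among the compounds named here.

In an ADME assay on TZM cells (Homo sapiens) for cytotoxicity, read by MTT assay, with a stated time of 48 h (a higher number here means that more compound is tolerated, a lower number that less compound is tolerated), compound 1 `Cc1ccc(NS(=O)(=O)N2C(=O)CSC2c2c(F)cccc2Cl)cc1` gives 136000 nM. Compound 2 `COc1cc(OC)nc(N2C(=O)CSC2c2c(F)cccc2F)n1` gives 77500 nM in this assay, and compound 3 `COc1cc(OC)nc(N2C(=O)CSC2c2c(F)cccc2Cl)n1` gives 98200 nM. The difference between the core of compound 1 and the core of compound 2 is not broken down here. Compounds 2 and 3 differ by chloro in place of fluoro on an aromatic carbon, and this gave a 1.3-fold higher number from compound 2 to compound 3 (0.10 log units; within the scatter). Compound 4 `Cc1ccc(NS(=O)(=O)N2C(=O)CSC2c2c(Cl)cccc2Cl)cc1` is not yet measured; it differs from compound 1 by chloro in place of fluoro on an aromatic carbon, which is the same kind of change, though here the place is meta to a chloro group rather than meta to a fluoro group. Because a 1.3-fold higher number from compound 2 to compound 3 (0.10 log units; within the scatter) stayed within the scatter, compound 4 is expected to show a step of a 1.2-fold higher number from compound 1 to compound 4 (0.08 log units; within the scatter) in this assay. Compound 4 is therefore estimated at 165000 nM, between 85000 nM and 320000 nM.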

Compound 4, half-maximal cytotoxic concentration: 75700 nM
Estimate against measurement, compound 4: 2.2-fold (0.34 log units) above; measured number outside the range, below it.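

Putting chloro in place of fluoro on the core of compound 1, which turns 2-chloro-6-fluorophenyl into 2,6-dichlorophenyl, gives a 1.8-fold lower number from compound 1 to compound 4 (0.25 log units; within the scatter) in this assay. The same change on the two cores can now be set side by side: the same change on two cores in this assay, a 1.3-fold higher number (0.10 log units; within the scatter) from compound 2 to compound 3 and a 1.8-fold lower number (0.25 log units; within the scatter) from compound 1 to compound 4, 2.3-fold (0.36 log units) apart, within the scatter of two such steps. This shows no clear sign that the core alters what this change does in this assay, but it does not prove that the change carries over unaltered, as two small steps within the scatter can hide a modest real difference.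

The compounds shown leave open what happens in this assay when an amine or a carboxylic acid stands in that place on the ring instead of a halogen. They also leave open how this swap behaves on any third core.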